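A Fluoro Swap on Compound 2

The source may report more compounds than this note shows. Statements on the series, on what has been measured and on what is new or still open speak of the compounds shown alone.

Compound 1 `O=C(Nc1n[nH]c2c1CN(C(=O)c1ccccc1)C2)c1ccc(F)cc1` gives 3190 nM
Compound 2 `O=C(Nc1nn(C(=O)C2CC2)c2c1CN(C(=O)c1ccccc1)C2)c1ccccc1` gives 1240 nM

In a functional assay on HCT-116 cells (Homo sapiens) for cytotoxicity, read by sulforhodamine B assay, with a stated time of 48 h (a lower number here means a stronger inhibitor, a higher number a weaker inhibitor), compound 2 gives 1240 nM as the lower of the two numbers, and its gap to compound 1 lies beyond the usual scatter. Compound 3 `O=C(Nc1nn(C(=O)C2CC2)c2c1CN(C(=O)c1ccccc1)C2)c1ccc(F)cc1` changes compound 2 in one place, with fluoro in place of hydrogen on an aromatic carbon, so that phenyl becomes 4-fluorophenyl. Compound 1 also carries 4-fluorophenyl, but it differs from compound 2 in more than one place, so these two values do not show what this swap does alone. Among the compounds with values here, with no measured step for this change, no shift beyond the scatter is expected in this assay for compound 3. The estimated step of a 1.0-fold lower number from compound 2 to compound 3 (0.01 log units; within the scatter) is correspondingly small. For compound 3 the estimated value is 1200 nM (expected range 480 nM to 3000 nM).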

Compound 3, half-maximal inhibitory concentration: 2280 nM
Beside the measured number, compound 3's estimate is 1.9-fold (0.28 log units) below it, and the stated range covers the measured number.
By their numbers in this assay, from the lowest: compounds 2, 3 and 1 (each within the scatter of the next, the first and the last beyond it).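

In this assay, fluoro in place of hydrogen on this aromatic carbon gives (a 1.8-fold higher number from compound 2 to compound 3 (0.26 log units; within the scatter)), so the change from phenyl to 4-fluorophenyl, now seen on its own, does not move the number beyond the scatter. The other single change, cyclopropylcarbonyl in place of hydrogen on an aromatic nitrogen, gives (a 1.4-fold lower number from compound 1 to compound 3 (0.15 log units; within the scatter)), so with 4-fluorophenyl in place this step also stays within the scatter. Nothing at hand explains why either step is this small.

Still open, on these data alone, is whether another group on this aromatic carbon, such as chloro, methoxy or an amine, would shift the number beyond the scatter. Also open, as far as these compounds go, is how that nitrogen would behave with a different group, such as acetyl or a longer chain, in place of cyclopropylcarbonyl.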